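Amide side-chain variation on the shared core: ring in place of chain

The source may report more compounds than this note shows. Statements on the series, on what has been measured and on what is new or still open speak of the compounds shown alone.

Measured so far in an assay on SH-EP1 cells for agonist activity at Neuronal acetylcholine receptor; alpha4/beta2 (Homo sapiens), read by FLIPR and calcium flux; a lower number here means a smaller maximal response, a higher number a larger maximal response:
compound 1 `CCCC(=O)N1CC2CC(C1)N2` gives 120%;
compound 2 `O=C(C1CCCC1)N1CC2CC(C1)N2` gives 48%;
compound 3 `O=C(CC1C=CCC1)N1CC2CC(C1)N2` gives 89%.

Compound 1 stands highest of the three in this assay; compound 3 is nearest, compound 2 furthest, both beyond the scatter. Among the compounds with values here, the one single-point step recorded, a number 31 percentage points lower from compound 1 to compound 3 (beyond the scatter), shows that putting a ring onto the chain that hangs from the carbonyl of compound 1 costs a large part of the maximal response. Within the data shown here, compound 2, where a ring sits directly on the carbonyl carbon, shows a still lower value than compound 1; no single-point step connects those two, so their values only indicate the same direction.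

Compound 4 `O=C([C@H]1C[C@H]1F)N1CC2CC(C1)N2` is not yet measured. It differs from compound 1 by 2-fluorocyclopropyl in place of propyl on a carbonyl carbon. As in compound 2, the ring sits directly on the carbonyl carbon, so a downward step in this assay is expected, of a size between that seen for compound 3 and that shown by compound 2. The expected step is a number 55 percentage points lower from compound 1 to compound 4 (beyond the scatter). Compound 4 is thus estimated at 65%, in the range 35% to 100%.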

Compound 4, largest response reached (Emax), in percent of the reference or control that the assay uses: 110%
For compound 4 the middle estimate is 45 percentage points below the measured one, outside the stated range (above it).
By their numbers in this assay, from the lowest: compound 2; then compound 3; then compounds 4 and 1 (each within the scatter of the next).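

In this assay, replacing propyl with 2-fluorocyclopropyl on a carbonyl carbon gives a number 10 percentage points lower from compound 1 to compound 4 (within the scatter), so a ring directly on that carbon does not in itself lower the maximal response. Compound 2 at 48% and compound 4 at 110% carry different rings on the same carbonyl carbon, so the value of compound 2 cannot be read as applying to every ring there. No measurement on hand accounts for the difference between these two ring-bearing compounds.

The compounds shown do not separate the contribution of the fluorine from that of the three-membered ring, a question that plain cyclopropyl on the carbonyl carbon would address. Also open, going by these compounds, are the other stereoisomers of 2-fluorocyclopropyl and how cyclobutyl would read at this position.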